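From cyclohexyl to 4-methylphenyl in compound 4

The source may hold more compounds than are shown below. What is called first, only, known or untested is meant among the compounds shown, and "the series" means these compounds.

Values in a functional assay on HepG2 cells (Homo sapiens) for antiproliferative activity, read by MTT assay, with a stated time of 48 h; a higher number here means a weaker inhibitor, a lower number a stronger inhibitor
Compound 1 `Cc1cccc(NC(=O)Nc2cccc(CNc3nccnc3Cl)c2)c1` gives 11200 nM
Compound 2 `Cc1ccc(NC(=O)Nc2cccc(CNc3nccnc3Cl)c2)c(C)c1` gives 9290 nM
Compound 3 `O=C(Nc1cccc(CNc2nccnc2Cl)c1)NC1CCCCC1` gives > 40000 nM (a limit of the assay, not a number)

Among these three, compound 3 alone rests on a limit (the limit of > 40000 nM in this assay, at which 1 of the 3 values shown sits). Compound 4 `Cc1ccc(NC(=O)Nc2cccc(CNc3nccnc3Cl)c2)cc1` puts 4-methylphenyl in place of cyclohexyl on an amide-type nitrogen. Among the compounds with values here, two measured steps bear on this change, and both run the opposite way, each putting cyclohexyl in place of a methylated phenyl ring (an at least 3.5-fold higher number from compound 1 to compound 3 (0.55 log units; beyond the scatter)) and (an at least 4.3-fold higher number from compound 2 to compound 3 (0.63 log units; beyond the scatter)). Compound 1 and compound 2 lie within the scatter of each other (a 1.2-fold lower number from compound 1 to compound 2 (0.08 log units; within the scatter)), so the exact methyl pattern on the phenyl ring shows no measurable effect in these two compounds. Reversing those steps, a modest move to a lower number, meaning a stronger inhibitor, is expected in this assay. The estimate means an expected step (an at least 4.0-fold lower number from compound 3 to compound 4 (0.60 log units; beyond the scatter)). The estimate for compound 4 is 10000 nM (expected range 5000 nM to 20000 nM).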

Compound 4, half-maximal inhibitory concentration: 11500 nM
Estimate against measurement, compound 4: 1.2-fold (0.06 log units) below; measured number inside the range.
By their numbers in this assay, from the lowest: compounds 2, 1 and 4 (each within the scatter of the next). At a limit, above all of these: compound 3.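

In this assay, the third methylated phenyl ring on this amide-type nitrogen meets cyclohexyl directly, an at least 3.4-fold lower number from compound 3 to compound 4 (0.54 log units; beyond the scatter), and the gain seen with the two earlier rings holds for 4-methylphenyl as well. Where the methyl sits, and whether a second one is present, still makes no measurable difference, as a 1.0-fold higher number from compound 1 to compound 4 (0.01 log units; within the scatter) and a 1.2-fold higher number from compound 2 to compound 4 (0.09 log units; within the scatter) show, so all three methylated phenyl compounds form one group with cyclohexyl apart from it. The figure for compound 3 is a limit of the assay and not a number, so the full size of the gap stays unknown: the limit of > 40000 nM in this assay, at which 1 of the 4 values shown sits.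

Going from cyclohexyl to 4-methylphenyl changes the ring and adds a methyl in one step, so a plain phenyl ring would be needed to separate the two. As far as these compounds go, how a chlorine, a methoxy group or a carboxylic acid on that ring would shift the number also remains open.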